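The source may report more compounds than this note shows. Statements on the series, on what has been measured and on what is new or still open speak of the compounds shown alone.

In a functional assay on HT-1080 cells (Homo sapiens) for cytotoxicity, read by MTT assay, with a stated time of 72 h (a higher number here means a weaker inhibitor, a lower number a stronger inhibitor), compound 2 (`COc1ccccc1/C=C1\CCC/C(=C\c2ccc(OC)c(OC)c2)C1=O`) gives 8100 nM, within the scatter of compound 1 (`COc1ccc(/C=C2\CCC/C(=C\c3cccc(OC)c3OC)C2=O)cc1OC`) at 6400 nM and compound 3 (`COc1ccc(/C=C2\CCC/C(=C\c3cccc(Cl)c3Cl)C2=O)cc1OC`) at 8800 nM. Compound 4 (`COc1ccc(/C=C2\CCC/C(=C\c3ccc(OC)c(OC)c3)C2=O)c(OC)c1`) differs from compound 2 by methoxy in place of hydrogen on an aromatic carbon, meta to a methoxy group and para to a large group. Going by the values given here, the closest precedent is a 1.3-fold higher number from compound 1 to compound 2 (0.10 log units; within the scatter), where hydrogen replaces methoxy on a different aromatic carbon. The swap to 2,3-dichlorophenyl, a 1.1-fold higher number from compound 2 to compound 3 (0.04 log units; within the scatter), is also small. No change beyond the scatter is therefore expected in this assay, and the estimated step is a 1.2-fold lower number from compound 2 to compound 4 (0.06 log units; within the scatter). For compound 4 the expected value is 7000 nM, within an estimated range of 3500 nM to 14000 nM.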

Compound 4, half-maximal inhibitory concentration: 17100 nM
Compound 4: the middle estimate sits 2.4-fold (0.39 log units) below what was measured, outside the stated range (above it).
By their numbers in this assay, from the lowest: compounds 1, 2, 3 and 4 (each within the scatter of the next, the first and the last beyond it).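

In this assay methoxy in place of hydrogen on this aromatic carbon, meta to a methoxy group and para to a large group, gives a 2.1-fold higher number from compound 2 to compound 4 (0.32 log units; beyond the scatter) and is the only single step shown that lies beyond the scatter. Hydrogen in place of methoxy on a different aromatic carbon gives a 1.3-fold higher number from compound 1 to compound 2 (0.10 log units; within the scatter) and stays within it, so among these compounds the carbon carrying the methoxy matters. Nothing available explains why this position responds.

At this carbon only hydrogen and methoxy can be compared. From the compounds shown here alone, whether an amine or a hydroxyl there would shift the number in the same way remains open.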